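Compound 3 to compound 4: methoxymethyl for oxan-4-yl

The source may hold more compounds than are shown below. What is called first, only, known or untested is meant among the compounds shown, and "the series" means these compounds.

Measured in an ADME assay on microsomes from liver (Rattus norvegicus) for metabolic stability; a lower number here means slower removal, a higher number faster removal of the compound:
- compound 1 `CO[C@H](C)c1c(NC(=O)Nc2cnc(-n3nccn3)c(Cl)c2)cnc2cc(Cl)nn12`: < 25 mL.min-1.g-1 (a limit)
- compound 2 `CO[C@@H](C)c1c(NC(=O)Nc2cnc(-n3nccn3)c(Cl)c2)cnc2cc(Cl)nn12`: < 25 mL.min-1.g-1 (a limit)
- compound 3 `O=C(Nc1cnc(-n2nccn2)c(Cl)c1)Nc1cnc2cc(Cl)nn2c1C1CCOCC1`: 25.5 mL.min-1.g-1

Going by the values given here, compound 3 gives 25.5 mL.min-1.g-1, the only actual number in the set. The other two results are limits of the assay.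

Compound 4 `COCc1c(NC(=O)Nc2cnc(-n3nccn3)c(Cl)c2)cnc2cc(Cl)nn12` differs from compound 3 as follows: methoxymethyl in place of oxan-4-yl on an aromatic carbon. It carries methoxymethyl in place of oxan-4-yl on an aromatic carbon.

The nearest measured changes are an at least 1.0-fold higher number from compound 1 to compound 3 (0.00 log units; that floor lies within the scatter) and an at least 1.0-fold higher number from compound 2 to compound 3 (0.00 log units; that floor lies within the scatter), each with oxan-4-yl in place of 1-methoxyethyl. Both floors lie within the scatter, and a step that the two limits leave unreadable from compound 1 to compound 2 adds no readable size. No step beyond the scatter is expected in this assay, and the expected change is a 1.3-fold lower number from compound 3 to compound 4 (0.11 log units; within the scatter). For compound 4 the estimated value is 20 mL.min-1.g-1, with an expected range of 10 mL.min-1.g-1 to 40 mL.min-1.g-1.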

Compound 4, intrinsic clearance in microsomes: < 25 mL.min-1.g-1
Compound 4: a limit, no number (the forecaster's own chance of this, stated with the estimate: 60%); the middle value does not contradict the limit.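

In this assay compound 4 gives < 25 mL.min-1.g-1 as a limit, not a number. Replacing oxan-4-yl with methoxymethyl gives an at least 1.0-fold lower number from compound 3 to compound 4 (0.00 log units; that floor lies within the scatter) and so shows no readable effect of losing the ring at this position, while the steps from compound 1 and compound 2 to compound 4 cannot be read, as both ends are limits. Differences at this position are largely hidden in this series: the limit of < 25 mL.min-1.g-1 in this assay, at which 3 of the 4 values shown sit.

Open, as far as these compounds go, is whether any group here moves the read-out beyond the scatter. An amine or a carboxylic acid on this chain would test that.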